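The compounds below may be only part of what the source reports. "The series", "measured", "known", "first", "only" and "open" are said of these compounds alone.

In an assay on cells for inhibition of Amine oxidase [flavin-containing] A (Homo sapiens), read by fluorescence, with a stated time of 30 min, tested at 10 uM (on this read-out lower numbers stand for less inhibition and higher numbers for more inhibition at the one concentration tested (going by the name of the read-out)), compound 1 `O=C(/C=C/c1ccc(OCCCN2CCCC2)cc1)c1ccc(OCCCN2CCCC2)cc1O` gives < 5%, a limit of the assay rather than a number. Compound 2 `O=C(/C=C/c1ccc(OCCCCCCN2CCCC2)cc1)c1ccc(OCCCCCCN2CCCC2)cc1O` gives < 5% in this assay, again a limit and not a number, so compound 2 sits at the floor of what the assay reports, as shown by the limit of < 5% in this assay, at which 2 of the 2 values shown sit. Compound 3 `O=C(/C=C/c1ccccc1)c1ccc(OCCCCCCN2CCCC2)cc1O` is not yet measured. It differs from compound 2 as hydrogen in place of (6-(pyrrolidin-1-yl)hexyl)oxy on an aromatic carbon. With both measured compounds at the limit, no step beyond the scatter is expected, and the step expected is a number no lower from compound 2 to compound 3 (the limit leaves the size open). Compound 3 is estimated at 5%, within 0% to 20%.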

Compound 3, a percentage reported as inhibition, at one concentration (the size of the read-out at that concentration, not a potency): 9.5%
Beside the measured number, compound 3's estimate is 4.5 percentage points below it, and the stated range covers the measured number.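

Going by these compounds alone, with hydrogen in place of (6-(pyrrolidin-1-yl)hexyl)oxy on the aromatic carbon, this assay gives the only value shown that is a number rather than a limit, with a number at least 4.5 percentage points higher from compound 2 to compound 3 (that floor lies within the scatter). The group at this place is therefore not required for the small inhibition seen, and no gain can be claimed from its loss, as the printed floor of the step lies within the scatter. The true size of the step stays undefined: the limit of < 5% in this assay, at which 2 of the 3 values shown sit.

As far as these compounds go, whether a methoxy group on this aromatic carbon, or an amine on a shorter chain there, would move the read-out beyond the scatter remains open.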